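Swapping the aryl group on the ring amine of compound 2

This account rests on a few compounds, and the source may have more. Where it says the series, first, only, none or still open, it means among the compounds named here.

Measured compounds: compound 1 `CCCCCCCCn1cc(/C=C/C(=O)c2ccc(NC(=O)CN3CCN(c4ccccc4)CC3)cc2)nn1` 52400 nM; compound 2 `CCCCCCCCn1cc(/C=C/C(=O)c2ccc(NC(=O)CN3CCN(c4ccccc4F)CC3)cc2)nn1` 47100 nM; compound 3 `O=C(CN1CCN(c2ccccc2F)CC1)Nc1ccc(C(=O)/C=C/c2cn(Cc3ccc(Br)cc3)nn2)cc1` 14700 nM.

In a functional assay on A549 cells (Homo sapiens) for inhibition, read by MTT assay (a lower number here means a stronger inhibitor, a higher number a weaker inhibitor), compound 2 gives 47100 nM, the second highest of the three numbers; compound 1 sits closest, compound 3 furthest. Compound 4 `CCCCCCCCn1cc(/C=C/C(=O)c2ccc(NC(=O)CN3CCN(c4ccc([N+](=O)[O-])cc4)CC3)cc2)nn1` differs from compound 2 by 4-nitrophenyl in place of 2-fluorophenyl on an amine nitrogen in a ring. Of the measured steps, only a 1.1-fold lower number from compound 1 to compound 2 (0.05 log units; within the scatter) touched this same aryl ring, and it stayed within the scatter; a 3.2-fold lower number from compound 2 to compound 3 (0.51 log units; beyond the scatter) changed a different part of the molecule and does not bear on this ring. Within the data shown here, no measured step covers a nitro group here. The account therefore expects for compound 4 no step beyond the scatter in this assay, a 1.1-fold lower number from compound 2 to compound 4 (0.05 log units; within the scatter). Compound 4 is estimated at 42000 nM, within 15000 nM to 110000 nM.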

Compound 4, half-maximal inhibitory concentration: 45400 nM
Compound 4: the middle estimate sits 1.1-fold (0.03 log units) below what was measured, and the stated range covers the measured number.
By their numbers in this assay, from the lowest: compound 3; then compounds 4, 2 and 1 (each within the scatter of the next).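

Within this assay, 4-nitrophenyl in place of 2-fluorophenyl gives a 1.0-fold lower number from compound 2 to compound 4 (0.02 log units; within the scatter), and nitro in place of hydrogen on the aromatic carbon gives a 1.2-fold lower number from compound 1 to compound 4 (0.06 log units; within the scatter). The larger group, which brings hydrogen-bond acceptors, thus leaves the number as unchanged as fluoro did, so this aryl position shows no readable sensitivity across compound 1, compound 2 and compound 4. No outside evidence bears on this result. Going by these compounds, whether an amine or a carboxylic acid on this ring would move the number remains open, as does whether 4-nitrophenyl would behave alike in compound 3, which carries the 4-bromophenyl group.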